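From butyl to chloro on a shared core

A few compounds are considered here, and "the series" means these few. Any claim that something is new, unique, unknown or untested is made for them only; others in the source may bear on it.

Compound 2 `CCCCc1ccc2[nH]cc(C(=O)OC)c(=O)c2c1` is the starting point in an ADME assay on J774 cells (Mus musculus) for cytotoxicity; a higher number here means that more compound is needed for the effect, a lower number that less compound is needed. Compound 2 gives > 20000 nM, which is a limit and not a number. Compound 1 `COC(=O)c1c[nH]c2cc(OCCOc3ccccc3)ccc2c1=O` gives > 20000 nM, also a limit. Together these two make up (the limit of > 20000 nM in this assay, at which 2 of the 3 values shown sit). Compound 3 `COC(=O)c1c[nH]c2cc(OCCCc3ccccc3)ccc2c1=O`, by contrast, gives a true number, 1480 nM. Among the measured compounds shown here, the one measured step, an at least 13-fold lower number from compound 1 to compound 3 (1.13 log units; beyond the scatter), is large and comes with benzyl in place of phenoxy on a saturated chain carbon, so it bears on the present change only indirectly.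

Compound 4 `COC(=O)c1c[nH]c2ccc(Cl)cc2c1=O` differs from compound 2 by chloro in place of butyl on an aromatic carbon. For the measured compounds named here, it lacks the chain of compound 3, the only compound here with a number, at 1480 nM. No step beyond the scatter is therefore expected in this assay, and a reading at the limit is the likeliest outcome. The estimated step is a step that the limit leaves unreadable from compound 2 to compound 4. Compound 4 is expected at about 25000 nM, within an estimated range of 10000 nM to 60000 nM.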

Compound 4, half-maximal effective concentration: > 20000 nM
Compound 4 was reported as a limit; the forecaster's own chance of this, stated with the estimate: 80%; the middle value lies beyond the limit too.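

Compound 2 and compound 4 are both reported only as limits in this assay, so no step can be read between them: the limit of > 20000 nM in this assay, at which 3 of the 4 values shown sit.

The compounds shown leave open whether chloro in place of butyl on an aromatic carbon changes the true number at all.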